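The source may report more compounds than this note shows. Statements on the series, on what has been measured and on what is new or still open speak of the compounds shown alone.

Compound 1 `CCCCOc1ccc(-c2nc3ncccn3c2NC(C)(C)CC(C)(C)C)cc1`: 29000 nM
Compound 2 `CCCCOc1ccc(-c2nc3ncccn3c2NCc2ccc(OC)cc2)cc1`: 55000 nM

For the measured compounds named here, in a toxicity assay on A549 cells (Homo sapiens) for cytotoxicity, read by luminescence and CellTiter-Glo, with a stated time of 48 h (on this read-out higher numbers stand for lower toxicity in this test and lower numbers for higher toxicity in this test), compound 2 gives 55000 nM, the highest of the two numbers, with compound 1 nearest; the only measured step, a 1.9-fold higher number from compound 1 to compound 2 (0.28 log units; within the scatter), changes the group on the ring nitrogen and stays within the scatter. Compound 3 `CCCCOc1ccc(-c2nc3ncccn3c2NCc2nc[nH]c2C)cc1` differs from compound 2 by 5-methyl-1H-imidazol-4-yl in place of 4-methoxyphenyl on a saturated chain carbon bound to a nitrogen on an aromatic ring. That one step bears on it only loosely, as no measured change introduces a five-membered aromatic ring with two hetero atoms. The expected step is a 1.1-fold lower number from compound 2 to compound 3 (0.04 log units; within the scatter), nothing beyond the scatter. Compound 3 is estimated at 50000 nM, with a range from 18000 nM to 140000 nM.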

Compound 3, half-maximal cytotoxic concentration: 100000 nM
Beside the measured number, compound 3's estimate is 2.0-fold (0.30 log units) below it, and the stated range covers the measured number.
By their numbers in this assay, from the lowest: compounds 1, 2 and 3 (each within the scatter of the next, the first and the last beyond it).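

In this assay, 5-methyl-1H-imidazol-4-yl in place of 4-methoxyphenyl gives a 1.8-fold higher number from compound 2 to compound 3 (0.26 log units; within the scatter), so exchanging a six-membered carbon ring for a five-membered aromatic ring with 2 hetero atoms has no effect that can be told from the scatter. Against the 1,1,3,3-tetramethylbutyl group, (5-methyl-1H-imidazol-4-yl)methyl gives a 3.4-fold higher number from compound 1 to compound 3 (0.54 log units; beyond the scatter), the first step on this nitrogen to clear the scatter, though only a modest one, towards lower toxicity in this test. Nothing available explains this result.

The compounds shown leave open whether the methyl on the imidazole ring matters. They also leave open how a carboxylic acid or an amine on the group at this nitrogen would read in this test.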